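Working notes on compounds 1 to 4

The source may report more compounds than this note shows. Statements on the series, on what has been measured and on what is new or still open speak of the compounds shown alone.

Measured in a functional assay on HL-60 cells (Homo sapiens) for cytotoxicity, read by MTT assay, with a stated time of 48 h; on this read-out lower numbers stand for stronger inhibition and higher numbers for weaker inhibition:
Compound 1 `Fc1cccc(-c2nc(Nc3ccccc3)c3cc(F)ccc3n2)c1` gives 48300 nM.
Compound 2 `Fc1ccc(Nc2nc(-c3cccc(F)c3)nc3ccc(F)cc23)cc1` gives > 50000 nM, a limit of the assay and not a number.
Compound 3 `Fc1cccc(-c2nc(Nc3ccc(Br)cc3)c3cc(F)ccc3n2)c1` gives > 50000 nM, likewise a limit.

Compound 2 thus stands at the top of the read-out in this assay; the set is dominated by the limit of > 50000 nM in this assay, at which 2 of the 3 values shown sit, and only compound 1 returns a number. The change to compound 4 `Fc1cccc(-c2nc(Nc3cccc(Br)c3)c3cc(F)ccc3n2)c1` is 3-bromophenyl in place of 4-fluorophenyl on a nitrogen on an aromatic ring. Among the compounds with values here, no measured step matches it directly. The nearest are an at least 1.0-fold higher number from compound 1 to compound 2 (0.01 log units; that floor lies within the scatter) and an at least 1.0-fold higher number from compound 1 to compound 3 (0.01 log units; that floor lies within the scatter), both floors that lie within the scatter, while a step that the two limits leave unreadable from compound 2 to compound 3. The bromo-bearing compound 3 gave no number at all, and compound 1 with plain phenyl sits close to the limit. For compound 4 the expectation in this assay is therefore a step that the limit leaves unreadable from compound 2 to compound 4, nothing beyond the scatter, and most probably once more a limit rather than a number. The estimate for compound 4 is 60000 nM, within 30000 nM to 150000 nM.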

Compound 4, half-maximal inhibitory concentration: > 50000 nM
Compound 4: only a limit was reported; the forecaster's own chance of this, stated with the estimate: 65%; the middle value lies beyond the limit too.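

In this assay compound 4 gives > 50000 nM, a limit of the assay and not a number. Within the data shown here, the only readable comparison is an at least 1.0-fold higher number from compound 1 to compound 4 (0.01 log units; that floor lies within the scatter), and the steps to compound 4 from compound 2 and compound 3 cannot be read. On this nitrogen, 3-bromophenyl now joins 4-bromophenyl and 4-fluorophenyl in returning no number, leaving compound 1 with plain phenyl as the only compound with a measured value, and the set is now held almost entirely at the top of the read-out: the limit of > 50000 nM in this assay, at which 3 of the 4 values shown sit.

With one number in the set, neither the identity nor the placing of the halogen can be given a size. Also open, on these data alone, is whether a phenyl carrying an amine or a carboxylic acid on this nitrogen would return a number at all.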